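The compounds below may be only part of what the source reports. "The series", "measured", "known", "first", "only" and "open" are said of these compounds alone.

Compound 1 `Cc1ccc(N/C(=N\C(=O)c2ccccc2)NCc2ccccc2)cc1`: 876000 nM
Compound 2 `O=C(/N=C(/NCc1ccccc1)Nc1ccc([N+](=O)[O-])cc1)c1ccccc1`: 802000 nM
Compound 3 `O=C(/N=C(/NCc1ccccc1)Nc1ccc(I)cc1)c1ccccc1`: 619000 nM

In an ADME assay on cells (Peritoneal macrophage, Mus musculus) for cytotoxicity, read by MTT assay, with a stated time of 24 h (on this read-out lower numbers stand for higher toxicity in this test and higher numbers for lower toxicity in this test), compound 1 gives the highest of the three numbers, yet its steps to compound 2 and to compound 3 both stay within the scatter, so no order among the three can be read from them. Compound 4 `O=C(/N=C(/NCc1ccccc1)Nc1ccc(F)cc1)c1ccccc1` differs from compound 1 in one place: fluoro in place of methyl on an aromatic carbon. Going by the values given here, two measured steps bear on this change, a 1.1-fold lower number from compound 1 to compound 2 (0.04 log units; within the scatter) and a 1.4-fold lower number from compound 1 to compound 3 (0.15 log units; within the scatter), each replacing the same methyl by another group on an aromatic carbon, and each within the scatter. A swap of this kind has so far produced no step beyond the scatter, so the step of a 1.1-fold lower number from compound 1 to compound 4 (0.04 log units; within the scatter) is expected to be small, with no clear direction. Compound 4 is therefore estimated at 800000 nM, with a range from 400000 nM to 1600000 nM.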

Compound 4, half-maximal cytotoxic concentration: 866000 nM
The estimate for compound 4 lay 1.1-fold (0.03 log units) below the measured number; the measured number falls inside the stated range.
By their numbers in this assay, from the lowest: compounds 3, 2, 4 and 1 (each within the scatter of the next).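

Fluoro is a fourth group on this aromatic carbon, and in this assay it stays within the scatter of the other three (a 1.0-fold lower number from compound 1 to compound 4 (0.00 log units; within the scatter)), (a 1.4-fold higher number from compound 3 to compound 4 (0.15 log units; within the scatter)) and (a 1.1-fold higher number from compound 2 to compound 4 (0.03 log units; within the scatter)). Methyl, nitro, iodo and fluoro therefore cannot be told apart at this position by this read-out, and every swap among them now lies within the scatter. Nothing measured here offers a reason for this.

As far as these compounds go, whether an amine, a carboxylic acid or a longer chain on this carbon would move the number remains open. So does the effect of any change elsewhere on the shared core.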